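The source may hold more compounds than are shown below. What is called first, only, known or untested is meant among the compounds shown, and "the series" means these compounds.

Working notes on the quinoxaline-derived amine series measured in an assay on isolated protein for inhibition of Dihydrofolate reductase (Homo sapiens), read by spectrophotometry; on this read-out lower numbers stand for stronger inhibition and higher numbers for weaker inhibition.

Compound 1 `CN(Cc1nc2cc(C(F)(F)F)ccc2nc1-c1ccccc1)c1ccc(OC(F)(F)F)cc1` gives 3000 nM in this assay. Compound 2 `COc1ccc(N(C)Cc2nc3cc(C(F)(F)F)ccc3nc2-c2ccccc2)cc1OC` gives 8000 nM, and compound 3 `C#CCN(Cc1nc2cc(C(F)(F)F)ccc2nc1-c1ccccc1)c1ccc(OC(F)(F)F)cc1` gives 4000 nM. The step of a 2.7-fold higher number from compound 1 to compound 2 (0.43 log units; beyond the scatter) comes from 3,4-dimethoxyphenyl in place of 4-(trifluoromethoxy)phenyl on an amine nitrogen. The step of a 1.3-fold higher number from compound 1 to compound 3 (0.12 log units; within the scatter) comes from ethynyl in place of hydrogen on a saturated chain carbon bound to a nitrogen on an aromatic ring; this is also how the cores of compound 3 and compound 4 differ from those of compound 1 and compound 2.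

Compound 4 `C#CCN(Cc1nc2cc(C(F)(F)F)ccc2nc1-c1ccccc1)c1ccc(OC)c(OC)c1` is not yet measured in this assay. It differs from compound 3 by 3,4-dimethoxyphenyl in place of 4-(trifluoromethoxy)phenyl on an amine nitrogen, which is the same change as that from compound 1 to compound 2, made at the same place on the amine nitrogen. Among the measured compounds shown here, only one earlier instance of this change exists, so the expectation for compound 4 rests on a single step. A step of about a 2.5-fold higher number from compound 3 to compound 4 (0.40 log units; beyond the scatter) is expected, resting on the step of a 2.7-fold higher number from compound 1 to compound 2 (0.43 log units; beyond the scatter) applied to compound 3 at 4000 nM. The estimate for compound 4 in this assay is 10000 nM, with an expected range from 5000 nM to 25000 nM.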

Compound 4, inhibition constant: 3000 nM
Compound 4: middle estimate off by 3.3-fold (0.52 log units), on the high side; measured number outside the range, below it.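

In this assay, 3,4-dimethoxyphenyl in place of 4-(trifluoromethoxy)phenyl on the amine nitrogen gives a 1.3-fold lower number from compound 3 to compound 4 (0.12 log units; within the scatter), and ethynyl in place of hydrogen on the saturated chain carbon gives a 2.7-fold lower number from compound 2 to compound 4 (0.43 log units; beyond the scatter). The aryl change does not carry over unaltered from one core to the other: the same change on two cores in this assay, a 2.7-fold higher number (0.43 log units; beyond the scatter) from compound 1 to compound 2 and a 1.3-fold lower number (0.12 log units; within the scatter) from compound 3 to compound 4, 3.6-fold (0.55 log units) apart, beyond the scatter of two such steps. The ethynyl change, read across the same four compounds, does not carry over either, but this rests on a single set of four compounds and does not show why the steps disagree or whether the same would hold for other pairs in the series: the same change on two cores in this assay, a 1.3-fold higher number (0.12 log units; within the scatter) from compound 1 to compound 3 and a 2.7-fold lower number (0.43 log units; beyond the scatter) from compound 2 to compound 4, 3.6-fold (0.55 log units) apart, beyond the scatter of two such steps.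

The compounds shown leave open whether this dependence on the partner group is tied to the ethynyl group or also appears with a plain longer chain, such as propyl, on the amine nitrogen. They also leave open whether other aryl groups, such as unsubstituted phenyl or 4-methoxyphenyl, would follow the step seen on one core or on the other.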